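Changing the Aryl Ring of Compound 1: An Expectation

The compounds below may be only part of what the source reports. "The series", "measured", "known", "first", "only" and "open" are said of these compounds alone.

Measured so far:
compound 1, `CCCN(CC1CC1)c1nc(C)nc2c1n(C)c(=O)n2-c1ccc(C(C)C)cc1Br` — 5.7 nM
compound 2, `COCCNc1nc(C)nc2c1n(C)c(=O)n2-c1ccc(C(C)C)cc1Br` — 1180 nM

In an assay on HEK293 cells for binding affinity to corticotropin-releasing factor receptor 1 (Homo sapiens), read by radioligand binding (a higher number here means a weaker inhibitor, a lower number a stronger inhibitor), compound 1 gives 5.7 nM, the lower of the two numbers. For the measured compounds named here, compound 2 gives 1180 nM in this assay, and the only measured step, a 210-fold higher number from compound 1 to compound 2 (2.32 log units; beyond the scatter), is a large one at the amine on the shared core.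

Compound 3, `CCCN(CC1CC1)c1nc(C)nc2c1n(C)c(=O)n2-c1c(C)cc(C)cc1C`, differs from compound 1 elsewhere: 2,4,6-trimethylphenyl in place of 2-bromo-4-isopropylphenyl on an aromatic nitrogen. Going by the values given here, no measured step bears on this change; the single step from compound 1 to compound 2 concerns the amine, which compound 3 keeps. The aryl ring exchange therefore carries no guidance from the data, and the expected step is one that stays near or somewhat beyond the scatter, most likely toward a slightly higher number. Compound 3 is estimated at 10 nM in this assay, with a range of 3 nM to 40 nM. The estimated step from compound 1 is a 1.8-fold higher number from compound 1 to compound 3 (0.24 log units; within the scatter).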

Compound 3, inhibition constant: 6.1 nM
Estimate against measurement, compound 3: 1.6-fold (0.21 log units) above, within the range that was stated.
By their numbers in this assay, from the lowest: compounds 1 and 3 (each within the scatter of the next); then compound 2.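

Exchanging 2-bromo-4-isopropylphenyl for 2,4,6-trimethylphenyl on the aromatic nitrogen gives a 1.1-fold higher number from compound 1 to compound 3 (0.03 log units; within the scatter) in this assay, so this pair shows that, with the amine of compound 1 kept, an aryl ring without bromine or isopropyl can give a value that cannot be told apart from that of compound 1. The earlier data showed only that this assay responds strongly to a change at the amine, with a 210-fold higher number from compound 1 to compound 2 (2.32 log units; beyond the scatter), and said nothing about the aryl ring. Nothing shown explains why these two aryl groups give matching results.

Going by these compounds, whether a 2,4-dichlorophenyl group or a pyridine ring on the same nitrogen would also stay within the scatter remains open. So does whether 2,4,6-trimethylphenyl would match 2-bromo-4-isopropylphenyl when paired with the (2-methoxyethyl)amino group of compound 2.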